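The source may hold more compounds than are shown below. What is called first, only, known or untested is meant among the compounds shown, and "the series" means these compounds.

Measured compounds:
Compound 1, `Clc1[nH]ccc2ncnc1-2`: in a functional assay on the whole organism (Pleural cavity) with Rattus norvegicus as the target (on this read-out higher numbers stand for an effect only at larger amounts of compound and lower numbers for an effect already at smaller amounts), compound 1 reaches only the assay limit, > 9 mg/kg.
Compound 2, `OCCNc1[nH]ccc2ncnc1-2`: in this assay compound 2 likewise reaches only the assay limit, > 9 mg/kg.
Compound 3, `Nc1[nH]ccc2ncnc1-2`: in this assay compound 3 gives 8 mg/kg.

For the measured compounds named here, compound 3 thus stands as the only compound of the three with a number in this assay; the other two values are limits. Compound 4, `CSc1[nH]ccc2ncnc1-2`, is not yet measured. It differs from compound 3 in one place: methylsulfanyl in place of amino on an aromatic carbon.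

Two measured steps lead into compound 3 and so bear on this change. The step of an at least 1.1-fold lower number from compound 1 to compound 3 (0.05 log units; that floor lies within the scatter) and the step of an at least 1.1-fold lower number from compound 2 to compound 3 (0.05 log units; that floor lies within the scatter) both end at the one number shown; the step that the two limits leave unreadable from compound 1 to compound 2 cannot be read because of the limit of > 9 mg/kg in this assay, at which 2 of the 3 values shown sit. Going by the values given here, no measured step carries methylsulfanyl, so the size of the step to compound 4 is not fixed by the data; what the two limits and one number show is that the read-out in this set tends toward (the limit of > 9 mg/kg in this assay, at which 2 of the 3 values shown sit).

Compound 4 is therefore expected to sit near that limit, with the step of a 1.1-fold higher number from compound 3 to compound 4 (0.05 log units; within the scatter) not clearly beyond the scatter. The estimate for compound 4 in this assay is 9 mg/kg, within a range from 4 mg/kg to 20 mg/kg.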

Compound 4, dose for half-maximal effect: 9 mg/kg
Compound 4: the middle estimate sits on the measured number at the digits printed; the range from low to high includes it.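

In this assay, the position on an aromatic carbon next to the ring nitrogen now carries two groups with readable numbers, and the change from amino to methylsulfanyl gives a 1.1-fold higher number from compound 3 to compound 4 (0.05 log units; within the scatter). Methylsulfanyl brings 0 hydrogen-bond donors where amino has 1, and it has 2 heavy atoms where amino has 1, yet the two values cannot be told apart, so within this one pair neither count separates the compounds. The steps of a number no higher from compound 1 to compound 4 (the limit leaves the size open) and a number no higher from compound 2 to compound 4 (the limit leaves the size open) cannot be read, because both start from a limit of the assay: the limit of > 9 mg/kg in this assay, at which 2 of the 4 values shown sit.

The one new step that can be read is a 1.1-fold higher number from compound 3 to compound 4 (0.05 log units; within the scatter), and the compounds shown leave open whether any group at this position can give a number clearly beyond the scatter. As far as these compounds go, how a methoxy group, a dimethylamino group or a longer alkylsulfanyl chain would read here also remains open, as does whether the sulfur of methylsulfanyl matters at all when compared with a plain methyl group.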